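The compounds below may be only part of what the source reports. "The series", "measured", "known", "first", "only" and "open" are said of these compounds alone.

Compound 1 (`O=C(O)COC1CCN(CCN(C(=O)c2ccc(F)cc2)c2ccc(Cl)cc2)CC1`): 2000 nM
Compound 2 (`O=C(O)COC1CCN(CCN(C(=O)c2ccc(C(F)(F)F)cc2)c2ccc(Cl)cc2)CC1`): > 10000 nM

Both compounds were tested in a functional assay on a cell-free system (Platelet, plasma, Homo sapiens) for inhibition; on this read-out lower numbers stand for stronger inhibition and higher numbers for weaker inhibition. Compound 2 gives > 10000 nM, which is a limit of the assay and not a number.

Compound 3 (`O=C(O)COC1CCN(CCN(C(=O)c2cccc(F)c2)c2ccc(Cl)cc2)CC1`) keeps the core of compound 2 but carries 3-fluorophenyl in place of 4-(trifluoromethyl)phenyl on a carbonyl carbon. Within the data shown here, one measured step bears on this change: an at least 5.0-fold higher number from compound 1 to compound 2 (0.69 log units; beyond the scatter), with trifluoromethyl in place of fluoro on an aromatic carbon. Compound 3 carries fluoro again, as compound 1 does, so that step is read in reverse and a move toward lower numbers is expected in this assay. The estimated step is an at least 4.0-fold lower number from compound 2 to compound 3 (0.60 log units; beyond the scatter). Among the measured compounds shown here, no measured step covers 3-fluorophenyl itself, so the range stays wide. Compound 3 is expected at an estimated 2500 nM, with a range from 700 nM to 9000 nM.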

Compound 3, half-maximal inhibitory concentration: 340 nM
Compound 3: the middle estimate sits 7.4-fold (0.87 log units) above what was measured; the measured number lies below the stated range.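

In this assay, 3-fluorophenyl in place of 4-fluorophenyl on a carbonyl carbon gives a 5.9-fold lower number from compound 1 to compound 3 (0.77 log units; beyond the scatter), so with the same substituent on the ring, where the fluoro sits changes the result, which compound 1 and compound 2 alone could not show. Set against 4-(trifluoromethyl)phenyl, the same group gives an at least 29-fold lower number from compound 2 to compound 3 (1.46 log units; beyond the scatter). That size is only a bound, because compound 2 holds a limit of the assay and not a number: the limit of > 10000 nM in this assay, at which 1 of the 3 values shown sits.

The compounds shown leave open whether the lower number belongs to fluoro in particular, since 3-chlorophenyl or 3-methoxyphenyl do not appear among them. They also leave open whether the step from 4-fluorophenyl to 3-fluorophenyl would hold if the carboxylic acid stood on a longer chain.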